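This account rests on a few compounds, and the source may have more. Where it says the series, first, only, none or still open, it means among the compounds named here.

Measured in a functional assay on DLD-1 cells (Homo sapiens) for antiproliferative activity, read by sulforhodamine B assay, with a stated time of 48 h; a lower number here means a stronger inhibitor, a higher number a weaker inhibitor:
- Compound 1 `CCCCN(C)C(=O)CCCOc1cc(OC)c(OC)c2oc(-c3ccc(OC)cc3)c(O)c(=O)c12`: > 40000 nM, a limit
- Compound 2 `COc1ccc(-c2oc3c(OC)c(OC)cc(OCCCC(=O)NCc4ccccn4)c3c(=O)c2O)cc1`: > 40000 nM, a limit
- Compound 3 `CCCCN(C)C(=O)CCCCOc1cc(OC)c(OC)c2oc(-c3ccc(OC)cc3)c(O)c(=O)c12`: 17400 nM

Compound 2 stands at the limit of > 40000 nM in this assay, at which 2 of the 3 values shown sit, so it has a limit and not a true number. Compound 4 `COc1ccc(-c2oc3c(OC)c(OC)cc(OCCCCC(=O)N4CCN(C)CC4)c3c(=O)c2O)cc1` differs from compound 2 as follows: ((4-methylpiperazin-1-yl)carbonyl)methyl in place of ((pyridin-2-yl)methyl)carbamoyl on a saturated chain carbon, three bonds along the chain from an oxygen on an aromatic ring.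

Among the measured compounds shown here, two measured steps bear on this change. The closest is an at least 2.2-fold lower number from compound 1 to compound 3 (0.36 log units; beyond the scatter), where (butyl(methyl)carbamoyl)methyl replaces butyl(methyl)carbamoyl at the same place, and compound 4 likewise carries a group ending in carbonyl)methyl. The second is an at least 2.2-fold lower number from compound 2 to compound 3 (0.36 log units; beyond the scatter), which reaches the same compound 3 from the starting point here. Changing only the group on the carbonyl carbon gave a step that the two limits leave unreadable from compound 1 to compound 2, so that step offers no size to borrow.

A modest move towards a lower number therefore seems likely, with compound 3 at 17400 nM as the guide. The expected change is an at least 1.8-fold lower number from compound 2 to compound 4 (0.25 log units; that floor lies within the scatter), although the assay may again report only a limit. Compound 4 is estimated at 22000 nM, with an expected range of 9000 nM to 40000 nM.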

Compound 4, half-maximal inhibitory concentration: > 40000 nM
Compound 4 ended at the assay's limit; the forecaster's own chance of this, stated with the estimate: 35%; at least 1.8-fold (0.25 log units) between middle value and limit.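

The longer chain does not bring measurable activity by itself. Among the compounds shown here, with that chain kept, 4-methylpiperazin-1-yl in place of butyl(methyl)amino on the carbonyl carbon gives an at least 2.2-fold higher number from compound 3 to compound 4 (0.36 log units; beyond the scatter), so the group on the carbonyl carbon counts at this chain length, a point the earlier compounds could not show. The steps from compound 1 and from compound 2 to compound 4 join two limits and cannot be read, and only compound 3 has a true number: the limit of > 40000 nM in this assay, at which 3 of the 4 values shown sit.

The compounds shown leave open whether another amine on the carbonyl carbon, such as piperidine or dibutylamine, would match or pass compound 3. They also leave open how a longer chain, or a carboxylic acid in place of the amide, would read in this assay.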